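Amino for Dimethylamino on the Longer Side Chain

The source may hold more compounds than are shown below. What is called first, only, known or untested is meant among the compounds shown, and "the series" means these compounds.

Measured compounds:
compound 1, `CCCCCCCCCC(CCO)n1cnc2c(N(C)C)ncnc21`, 9810 nM
compound 2, `CCCCCCCCCC(CCO)n1cnc2c(N)ncnc21`, 10500 nM
compound 3, `CCCCCCCCCCC(CCO)n1cnc2c(N(C)C)ncnc21`, 5490 nM

In a functional assay on HCT-116 cells (Homo sapiens) for antiproliferative activity, read by MTT assay, with a stated time of 48 h (on this read-out lower numbers stand for stronger inhibition and higher numbers for weaker inhibition), compound 1 gives 9810 nM, compound 2 gives 10500 nM and compound 3 gives 5490 nM. Compound 1 and compound 2 differ by amino in place of dimethylamino on an aromatic carbon, and this change made a step of a 1.1-fold higher number from compound 1 to compound 2 (0.03 log units; within the scatter). The cores of compound 1 and compound 3 differ by methyl in place of hydrogen on a saturated chain carbon, ten or more bonds along the chain from an aromatic nitrogen, with a step of a 1.8-fold lower number from compound 1 to compound 3 (0.25 log units; within the scatter). All three values lie within the scatter of one another, so no order among them is claimed.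

Compound 4, `CCCCCCCCCCC(CCO)n1cnc2c(N)ncnc21`, has not yet been measured in this assay. It differs from compound 3 by amino in place of dimethylamino on an aromatic carbon, the same change that was made from compound 1 to compound 2, on a core that carries the extra methyl. Since that earlier change left the number essentially unmoved, the step from compound 3 to compound 4 is expected to be a 1.1-fold higher number from compound 3 to compound 4 (0.04 log units; within the scatter), resting on a 1.1-fold higher number from compound 1 to compound 2 (0.03 log units; within the scatter) and on compound 3 giving 5490 nM. Compound 4 is therefore estimated at 6000 nM, with a range from 3000 nM to 12000 nM.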

Compound 4, half-maximal inhibitory concentration: 2590 nM
Estimate against measurement, compound 4: 2.3-fold (0.36 log units) above; measured number below the stated range.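

In this assay, amino in place of dimethylamino gives a 2.1-fold lower number from compound 3 to compound 4 (0.33 log units; beyond the scatter) on the core carrying the extra methyl, and set beside the step on the core of compound 1, this gap does not exceed what two such steps can show by chance: the same change on two cores in this assay, a 1.1-fold higher number (0.03 log units; within the scatter) from compound 1 to compound 2 and a 2.1-fold lower number (0.33 log units; beyond the scatter) from compound 3 to compound 4, 2.3-fold (0.36 log units) apart, within the scatter of two such steps. Methyl in place of hydrogen on the saturated chain carbon, read on the cores bearing amino, gives a 4.1-fold lower number from compound 2 to compound 4 (0.61 log units; beyond the scatter), and this step likewise cannot be separated from its earlier counterpart: the same change on two cores in this assay, a 1.8-fold lower number (0.25 log units; within the scatter) from compound 1 to compound 3 and a 4.1-fold lower number (0.61 log units; beyond the scatter) from compound 2 to compound 4, 2.3-fold (0.36 log units) apart, within the scatter of two such steps. Each change therefore carries across these two cores without a demonstrated difference, but two pairs cannot show that the steps are the same, nor that either change acts more strongly on one core than on the other.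

On these data alone, whether the same steps would hold for a methylamino group in place of amino, or for a still longer chain, remains open. So does the effect of a carboxylic acid in place of the alcohol.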